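The source may hold more compounds than are shown below. What is called first, only, known or untested is meant among the compounds shown, and "the series" means these compounds.

Measured so far in a physicochemical assay for lipophilicity, using the shake flask method, measured as octanol-water partition, at pH 7.4; on this read-out higher numbers stand for higher lipophilicity and lower numbers for lower lipophilicity:
compound 1 `COc1cc(/C=C/C(=O)Nc2ccccc2)ccc1OCCCCCN1CCCC1`: 1.64
compound 2 `CCN(CC)CCCCCCCCOc1ccc(/C=C/C(=O)Nc2ccccc2)cc1OC`: 1.75

Among the compounds with values here, compound 2 and compound 1 lie within the scatter of each other; the only step recorded between them is a number 0.11 log units higher from compound 1 to compound 2 (within the scatter). The next step leads from compound 2 to compound 3 `CCOC(=O)/C=C/c1ccc(OCCCCCCCCN(CC)CC)c(OC)c1`, where the change is ethoxy in place of anilino on a carbonyl carbon. Within the data shown here, the one measured step alters the amine end of the chain and leaves the carbonyl carbon untouched, so it does not bear on this change; no measured pair does. The expectation therefore rests on the structures alone, with wide uncertainty. For compound 3 the estimate in this assay is 1.4, with a range from 0.9 to 1.9. The expected step of a number 0.35 log units lower from compound 2 to compound 3 (beyond the scatter) is thus a modest downward one, at the edge of the scatter, to be confirmed by measurement.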

Compound 3, partition coefficient: 1.98
Beside the measured number, compound 3's estimate is 0.58 log units below it, and the stated range ends below it.
By their numbers in this assay, from the lowest: compounds 1, 2 and 3 (each within the scatter of the next, the first and the last beyond it).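

In this assay, within the data shown here, ethoxy in place of anilino on a carbonyl carbon gives a number 0.23 log units higher from compound 2 to compound 3 (within the scatter) and is the only reading so far at this position, as the earlier step changed only the amine end of the chain. Here the group that leaves holds a six-membered aromatic ring and a hydrogen-bond donor, and the group that enters holds neither, yet the step stays within the scatter. No evidence on these compounds accounts for this result.

Still open, from the compounds shown here alone, is whether a carboxylic acid, a primary amide or a longer alkoxy chain such as butoxy on the same carbonyl carbon would also stay within the scatter of compound 3. Also open, going by these compounds, is whether ethoxy in place of anilino reads the same when the chain ends in pyrrolidin-1-yl, as in compound 1.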